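Benzyl halogen pattern in the acylurea benzimidazole series

The compounds below may be only part of what the source reports. "The series", "measured", "known", "first", "only" and "open" are said of these compounds alone.

Compound 2 `Cc1ccc(NC(=O)NC(=O)c2ccc(OCc3ccccc3Cl)cc2)cc1-c1nc2ccccc2[nH]1` is the weaker of the two measured analogues in a functional assay on MNK45 cells (Homo sapiens) for inhibition, read by MTT assay, with a stated time of 48 h; a higher number here means a weaker inhibitor, a lower number a stronger inhibitor; compound 2 gives 21500 nM, which is the highest number of the pair. The nearest measured neighbour is compound 1 `Cc1ccc(NC(=O)NC(=O)c2ccc(OCc3ccccc3F)cc2)cc1-c1nc2ccccc2[nH]1`, for which compound 1 gives 1830 nM in this assay. Among the measured compounds shown here, the single measured step, a 12-fold higher number from compound 1 to compound 2 (1.07 log units; beyond the scatter), is the only comparison available and concerns a halogen swap at one place of the benzyl ring.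

Compound 3 `Cc1ccc(NC(=O)NC(=O)c2ccc(OCc3ccc(Cl)c(Cl)c3)cc2)cc1-c1nc2ccccc2[nH]1` carries a different change: 3,4-dichlorophenyl in place of 2-chlorophenyl on a saturated chain carbon bound to an oxygen on an aromatic ring. For the measured compounds named here, no measured step follows this route, so the step from compound 1 to compound 2 bears on it only indirectly, in that it shows the benzyl substitution moves the number in this assay by a large amount. The direction for compound 3 cannot be read from the two numbers; a shift back toward the number of compound 1 is as plausible as none beyond the scatter. The estimated step is a 2.7-fold lower number from compound 2 to compound 3 (0.43 log units; beyond the scatter). Compound 3 is therefore expected at about 8000 nM, with a range from 1500 nM to 40000 nM.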

Compound 3, half-maximal inhibitory concentration: 5820 nM
Compound 3: the middle estimate sits 1.4-fold (0.14 log units) above what was measured, and the stated range covers the measured number.
By their numbers in this assay, from the lowest: compound 1; then compound 3; then compound 2.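

In this assay, the change to 3,4-dichlorophenyl on a saturated chain carbon bound to an oxygen on an aromatic ring gives a 3.7-fold lower number from compound 2 to compound 3 (0.57 log units; beyond the scatter), so a chlorine on the benzyl ring does not by itself fix the number at the level of compound 2. The same group set against 2-fluorophenyl gives a 3.2-fold higher number from compound 1 to compound 3 (0.50 log units; beyond the scatter), leaving compound 1 with the lowest number of the three and showing that this position separates all three compounds beyond the scatter. No measurement at hand bears on what lies behind this order.

The step from 2-chlorophenyl to 3,4-dichlorophenyl alters both the number of chlorines and where they sit, so the compounds shown do not separate these two changes. Also open, as far as these compounds go, is how a plain phenyl ring, a bromine or a methoxy group at this position would compare with the halogen patterns, and whether an amine or a carboxylic acid on the benzyl ring would be accommodated in this assay.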